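A few compounds are considered here, and "the series" means these few. Any claim that something is new, unique, unknown or untested is made for them only; others in the source may bear on it.

Compound 1 `CCCn1c(=O)[nH]c2nc(-c3ccc(S(=O)(=O)N4CCN(c5ccccc5Br)CC4)cc3)[nH]c2c1=O`: 0.137 nM
Compound 2 `CCCn1c(=O)[nH]c2nc(-c3ccc(S(=O)(=O)N4CCN(c5ccccc5Cl)CC4)cc3)[nH]c2c1=O`: 0.403 nM

Both were tested in an assay on CHO cells for displacement of a labelled ligand from adenosine receptor A2b (Homo sapiens), read by scintillation counting, with a stated time of 75 min, in the presence of a further agent that is not named here; on this read-out lower numbers stand for stronger inhibition and higher numbers for weaker inhibition. Going by the values given here, compound 2 has the higher of the two numbers; its only neighbour is compound 1, and the step of a 2.9-fold higher number from compound 1 to compound 2 (0.47 log units; beyond the scatter) shows how far apart they lie. Compound 3 `CCCn1c(=O)[nH]c2nc(-c3ccc(S(=O)(=O)N4CCN(c5ccc(Cl)cc5F)CC4)cc3)[nH]c2c1=O` differs from compound 2 by 4-chloro-2-fluorophenyl in place of 2-chlorophenyl on an amine nitrogen in a ring. Among the compounds with values here, no measured step alters this part of the molecule in the same way; the single step known, chloro in place of bromo, was modest. A modest step is therefore expected, a 1.5-fold higher number from compound 2 to compound 3 (0.17 log units; within the scatter), with no clear pull in either direction. For compound 3 the estimate is 0.6 nM, ranging from 0.2 nM to 2 nM.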

Compound 3, inhibition constant: 1.91 nM
Estimate against measurement, compound 3: 3.2-fold (0.50 log units) below; the range from low to high includes it.
By their numbers in this assay, from the lowest: compound 1; then compound 2; then compound 3.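

The phenyl group on the ring nitrogen tolerates less change than the halogen swap suggested: in this assay, 4-chloro-2-fluorophenyl in place of 2-chlorophenyl gives a 4.7-fold higher number from compound 2 to compound 3 (0.68 log units; beyond the scatter), and in place of 2-bromophenyl it gives a 14-fold higher number from compound 1 to compound 3 (1.14 log units; beyond the scatter). This change moves the number further than chloro in place of bromo did. No measurement here explains the shift.

The new group swaps 2-chloro for 4-chloro and adds fluoro, and these compounds cannot separate the two changes. From the compounds shown here alone, how 2-fluorophenyl, 4-chlorophenyl or a methoxy-bearing phenyl would behave remains open.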